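The source may report more compounds than this note shows. Statements on the series, on what has been measured and on what is new or still open speak of the compounds shown alone.

Measured compounds in a functional assay on HT-29 cells (Homo sapiens) for inhibition, read by MTT assay, with a stated time of 48 h; a lower number here means a stronger inhibitor, a higher number a weaker inhibitor:
compound 1, `Cc1ccc(NC(=S)NC(=O)c2ccc(OCc3ccccc3)cc2)cc1-c1nc2ccccc2[nH]1`: 28800 nM
compound 2, `Cc1ccc(NC(=S)NC(=O)c2ccc(OCc3cccc(C(F)(F)F)c3)cc2)cc1-c1nc2ccccc2[nH]1`: 8200 nM
compound 3, `Cc1ccc(NC(=S)NC(=O)c2ccc(OCc3cccc(Cl)c3Cl)cc2)cc1-c1nc2ccccc2[nH]1`: 63700 nM

Compound 3 gives the highest number of the three; its nearest neighbour is compound 1, shown by a 2.2-fold higher number from compound 1 to compound 3 (0.34 log units; beyond the scatter), and its furthest is compound 2, shown by a 7.8-fold higher number from compound 2 to compound 3 (0.89 log units; beyond the scatter). Compound 4, `Cc1ccc(COc2ccc(C(=O)NC(=S)Nc3ccc(C)c(-c4nc5ccccc5[nH]4)c3)cc2)cc1`, is not yet measured in this assay. It differs from compound 3 in one place: 4-methylphenyl in place of 2,3-dichlorophenyl on a saturated chain carbon bound to an oxygen on an aromatic ring.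

Among the compounds with values here, two measured steps bear on this change, since both end at compound 3 and both alter the same ring on the saturated chain carbon bound to the oxygen. Going from the unsubstituted phenyl to the 2,3-dichlorophenyl raised the number, as seen in a 2.2-fold higher number from compound 1 to compound 3 (0.34 log units; beyond the scatter), and going from the 3-(trifluoromethyl)phenyl to it raised the number more, as seen in a 7.8-fold higher number from compound 2 to compound 3 (0.89 log units; beyond the scatter). Compound 4 carries a 4-methylphenyl, which resembles the phenyl of compound 1 more than the 2,3-dichlorophenyl of compound 3, so a return toward the number of compound 1 is expected, with the step estimated as a 2.5-fold lower number from compound 3 to compound 4 (0.41 log units; beyond the scatter). For compound 4 the estimate in this assay is 25000 nM, with a range from 9000 nM to 65000 nM.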

Compound 4, half-maximal inhibitory concentration: 14200 nM
The estimate for compound 4 lay 1.8-fold (0.25 log units) above the measured number; measured number inside the range.
By their numbers in this assay, from the lowest: compounds 2 and 4 (each within the scatter of the next); then compound 1; then compound 3.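

In this assay, the methyl of compound 4 gives a 2.0-fold lower number from compound 1 to compound 4 (0.31 log units; beyond the scatter), so trifluoromethyl is no longer the only substituent shown to lower the number relative to the unsubstituted phenyl, while the 2,3-dichlorophenyl of compound 3 goes against this pattern. The 4-methylphenyl and 3-(trifluoromethyl)phenyl groups are not separated, with a 1.7-fold higher number from compound 2 to compound 4 (0.24 log units; within the scatter) lying within the scatter, whereas replacing 2,3-dichlorophenyl gives a 4.5-fold lower number from compound 3 to compound 4 (0.65 log units; beyond the scatter), leaving compound 3 with a higher number than each of the other three compounds. No measurement available here accounts for these differences.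

From the compounds shown here alone, it remains open whether a single chlorine, rather than the two of compound 3, would lower or raise the number. Going by these compounds, the response of this assay to an amine or a carboxylic acid on the same ring also remains unknown.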